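The source may report more compounds than this note shows. Statements on the series, on what has been measured and on what is new or still open speak of the compounds shown alone.

Working notes on the carbamate/thiocarbamate series around the shared core of compound 1 `Cc1nc(S(C)(=O)=O)ccc1Oc1ncnc(OC2CCN(C(=O)OC(C)F)CC2)c1F`. In a functional assay on isolated protein for inhibition of Glucose-dependent insulinotropic receptor (Rattus norvegicus), read by HTRF and cAMP accumulation (a higher number here means that more compound is needed for the effect, a lower number that less compound is needed), compound 1 gives 315 nM. Compound 2 `Cc1nc(S(C)(=O)=O)ccc1Oc1ncnc(OC2CCN(C(=O)O[C@@H](C)C(F)(F)F)CC2)c1F` gives 109 nM in this assay, and compound 3 `Cc1nc(S(C)(=O)=O)ccc1Oc1ncnc(OC2CCN(C(=O)SC(C)C)CC2)c1F` gives 41.3 nM. Compound 3 therefore stands lowest of the three: it sits a 2.6-fold lower number from compound 2 to compound 3 (0.42 log units; beyond the scatter) and a 7.6-fold lower number from compound 1 to compound 3 (0.88 log units; beyond the scatter). The step of a 2.9-fold lower number from compound 1 to compound 2 (0.46 log units; beyond the scatter) is the other measured change, and all three measured steps concern the group on the carbonyl carbon.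

Compound 4 `Cc1nc(S(C)(=O)=O)ccc1Oc1ncnc(OC2CCN(C(=O)SC3CCC3)CC2)c1F` is the next member, not yet measured in this assay. It differs from compound 3 by cyclobutyl in place of isopropyl on a sulfur. Among the measured compounds shown here, none of the measured steps alters the substituent on the sulfur itself; the closest comparison is the isopropylsulfanyl of compound 3 against the two oxygen-linked groups of compound 1 and compound 2, which gave modest steps of the sizes stated. For the measured compounds named here, replacing isopropyl by cyclobutyl keeps the sulfur-linked thiocarbamate and adds only one carbon within a ring, so no step beyond the scatter is expected in this assay, in either direction. The expected step is a 1.2-fold lower number from compound 3 to compound 4 (0.07 log units; within the scatter). For compound 4 the estimate in this assay is 35 nM, with a range from 15 nM to 90 nM.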

Compound 4, half-maximal effective concentration: 77.4 nM
The estimate for compound 4 lay 2.2-fold (0.34 log units) below the measured number; low and high end bracket the measured number.
By their numbers in this assay, from the lowest: compounds 3, 4 and 2 (each within the scatter of the next, the first and the last beyond it); then compound 1.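

In this assay, among the compounds shown here, the first change on the sulfur itself, cyclobutyl in place of isopropyl, gives a step that does not separate the two groups (a 1.9-fold higher number from compound 3 to compound 4 (0.27 log units; within the scatter)), so this position accepts a four-membered carbon ring in place of the open isopropyl group with no change that can be read. The comparison with the oxygen-linked groups on the carbonyl carbon is now split: the thiocarbamate compound 3 stood clear of compound 2, but the cyclobutylsulfanyl group does not (a 1.4-fold lower number from compound 2 to compound 4 (0.15 log units; within the scatter)), while the gap to the 1-fluoroethyl carbamate remains (a 4.1-fold lower number from compound 1 to compound 4 (0.61 log units; beyond the scatter)). Sulfur on the carbonyl carbon therefore does not by itself set a compound apart from compound 2, and no data bear on why these steps take the sizes they do.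

Still open, going by these compounds, is whether a larger ring such as cyclohexyl or a longer chain such as n-butyl on the sulfur would give a step beyond the scatter. Also open, on these data alone, is whether isopropoxy or cyclobutoxy on the carbonyl carbon would match its sulfur counterpart, which would separate the effect of the linking atom from that of the group it carries.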